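Sec-butyl for methyl on sulfur: cytotoxicity notes

This account rests on a few compounds, and the source may have more. Where it says the series, first, only, none or still open, it means among the compounds named here.

Three compounds have readings so far, all at the top of the measured range. In a functional assay on MT4 cells (Homo sapiens) for cytotoxicity (a lower number here means that less compound is tolerated, a higher number that more compound is tolerated), compound 1 `CCC(C)Sc1nc(O)c(C)c(Cc2c(F)cccc2F)n1` gives 200000 nM, a true number. Compound 2 `CCC(C)Sc1nc(O)cc(C(C)c2c(F)cccc2F)n1` returns only a limit, > 200000 nM. Compound 3 `CSc1nc(O)c(C)c(C(C)c2c(F)cccc2F)n1` also returns only a limit, > 200000 nM. Compound 3 therefore stands on (the limit of > 200000 nM in this assay, at which 2 of the 3 values shown sit), and its true value is not known.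

Compound 4 `CCC(C)Sc1nc(O)c(C)c(C(C)c2c(F)cccc2F)n1` differs from compound 3 by sec-butyl in place of methyl on a sulfur. Going by the values given here, no measured pair isolates this change, so the expectation rests on indirect evidence. The sec-butyl group on sulfur is already present in compound 1, which gives 200000 nM. It is also present in compound 2, whose reading is the limit > 200000 nM. Neither reading points to marked cytotoxicity in this assay for compounds carrying this group.

The expected step of an at least 1.1-fold lower number from compound 3 to compound 4 (0.04 log units; that floor lies within the scatter) is small, probably within the scatter, and any movement is expected toward less compound being tolerated. A reading that again gives only a limit would fit this expectation. For compound 4 the estimated value is 180000 nM, with an expected range of 60000 nM to 300000 nM.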

Compound 4, half-maximal cytotoxic concentration: > 200000 nM
Compound 4 was reported as a limit (the forecaster's own chance of this, stated with the estimate: 55%); middle value at least 1.1-fold (0.04 log units) away from the limit.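

With sec-butyl in place of methyl on the sulfur, compound 4 stays at the limit of this assay, so the larger group brings no reading below that limit: the limit of > 200000 nM in this assay, at which 3 of the 4 values shown sit.

The steps to compound 4 from compound 3 and from compound 2 cannot be read, since both ends of each are limits, and neither the sec-butyl change on sulfur nor methyl in place of hydrogen on an aromatic carbon gets a size. Methyl in place of hydrogen on a saturated chain carbon bound to two aromatic carbons gives a number no lower from compound 1 to compound 4 (the limit leaves the size open), so this change shows no drop in the compound tolerated, though its size stays open.

On these data alone, how far the true values of compound 2, compound 3 and compound 4 lie beyond the limit remains open, and so does whether sec-butyl and methyl on sulfur differ at all in this read-out. Also open, as far as these compounds go, is whether a longer chain or an amine in that place would give a true number rather than a limit.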